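Changing the Aromatic Group on the Sulfonyl Sulfur

The source may hold more compounds than are shown below. What is called first, only, known or untested is meant among the compounds shown, and "the series" means these compounds.

Compound 1 `CCn1cc(C(=O)O)c(=O)c2cc(F)c(N3CCN(C(=N)NS(=O)(=O)c4ccc(C)cc4)CC3)cc21` was tested in a functional assay on A549 cells (Homo sapiens) for antiproliferative activity, read by MTT assay, with a stated time of 72 h (a lower number here means a stronger inhibitor, a higher number a weaker inhibitor), where compound 1 gives 71 nM. Compound 2 `N=C(NS(=O)(=O)c1ccccc1Cl)N1CCN(c2cc3c(cc2F)c(=O)c(C(=O)O)cn3C2CC2)CC1` gives 71 nM and compound 3 `Cc1ccc(S(=O)(=O)NC(=N)N2CCN(c3cc4c(cc3F)c(=O)c(C(=O)O)cn4C3CC3)CC2)cc1` gives 71 nM, so compound 1 stands level with both. Two single changes connect these three: no change at the digits printed from compound 1 to compound 3 (within the scatter) and no change at the digits printed from compound 2 to compound 3 (within the scatter). Compound 4 `CCn1cc(C(=O)O)c(=O)c2cc(F)c(N3CCN(C(=N)NS(=O)(=O)c4ccccc4C(F)(F)F)CC3)cc21` arises from compound 1 by one change, (2-(trifluoromethyl)phenyl in place of 4-methylphenyl on a sulfonyl sulfur). The second measured step bears on this, since it also exchanges the aromatic group on the sulfonyl sulfur, and that step stayed within the scatter. No move beyond the scatter is therefore expected in this assay, and the expected step is no change at the digits printed from compound 1 to compound 4 (within the scatter). Compound 4 is estimated at 71 nM, with a range from 35 nM to 145 nM.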

Compound 4, half-maximal inhibitory concentration: 71 nM
Estimate against measurement, compound 4: no gap at the digits printed; measured number inside the range.
By their numbers in this assay, from the lowest: compounds 1, 2, 3 and 4 (each within the scatter of the next).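

Adding 2-(trifluoromethyl)phenyl gives no change at the digits printed from compound 1 to compound 4 (within the scatter) in this assay. The earlier exchange on the sulfonyl sulfur belonged to the cyclopropyl series, whereas this one extends the flat result to the ethyl series and to a group of 10 heavy atoms, 3 of them fluorine, in place of one with 7. Nothing available explains why the values stay level.

All the groups shown on this sulfur are substituted phenyl rings. As far as these compounds go, whether a pyridine ring or a plain methyl group there would keep the same level remains open.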